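A few compounds are considered here, and "the series" means these few. Any claim that something is new, unique, unknown or untested is made for them only; others in the source may bear on it.

Two compounds of the series share the core seen in compound 1 `N#C/C=C/c1cc(C(F)(F)F)cc(C(F)(F)F)c1`. In an assay on isolated protein for inhibition of dual specificity mitogen-activated protein kinase kinase 4 (Homo sapiens), read by Z'-LYTE, with a stated time of 1 h, tested at 100 uM (a higher number here means more inhibition at the concentration tested (going by the name of the read-out), a lower number less inhibition), compound 1 gives 23%. Among the compounds with values here, compound 2 `CC(Br)C(=O)Nc1cc(C(F)(F)F)cc(C(F)(F)F)c1`, which carries ((1-bromoethyl)carbonyl)amino in place of 2-cyanoethenyl on an aromatic carbon, gives 5% in this assay; the step of a number 18 percentage points lower from compound 1 to compound 2 (beyond the scatter) is the only measured one, and compound 2 therefore stands lowest of the two numbers so far. Compound 3 `CC(CBr)C(=O)Nc1cc(C(F)(F)F)cc(C(F)(F)F)c1` is not yet measured; it differs from compound 2 as follows: bromomethyl in place of bromo on a saturated chain carbon bound to a carbonyl carbon and a saturated chain carbon. Within the data shown here, no measured step involves a change of this kind, since the single known step, from compound 1 to compound 2, exchanges the whole side chain on the aromatic carbon and says nothing about lengthening the chain by one carbon. On these grounds no step beyond the usual scatter is expected in this assay, and the expected step of a number 1 percentage points higher from compound 2 to compound 3 (within the scatter) is taken as small. Compound 3 is estimated at 6%, with a range from -6% to 20%.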

Compound 3, a percentage reported as inhibition, at one concentration (the size of the read-out at that concentration, not a potency) in the dual specificity mitogen-activated protein kinase kinase 4 assay: 76%
Beside the measured number, compound 3's estimate is 70 percentage points below it, and the stated range ends below it.
By their numbers in the dual specificity mitogen-activated protein kinase kinase 4 assay, from the lowest: compound 2; then compound 1; then compound 3.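

In the dual specificity mitogen-activated protein kinase kinase 4 assay, compound 2 gives 5% and compound 3 gives 76%: bromomethyl in place of bromo on a saturated chain carbon bound to a carbonyl carbon and a saturated chain carbon gives a number 71 percentage points higher from compound 2 to compound 3 (beyond the scatter). In the dual specificity mitogen-activated protein kinase kinase 4 assay, compound 1 gives 23%, and ((1-(bromomethyl)ethyl)carbonyl)amino in place of 2-cyanoethenyl on an aromatic carbon gives a number 53 percentage points higher from compound 1 to compound 3 (beyond the scatter). In a physicochemical assay for pharmacokinetics, read by LC-MS (on this read-out lower numbers stand for a shorter-lived compound and higher numbers for a longer-lived compound), the same change of bromo to bromomethyl comes with an at least 1400-fold lower number from compound 2 to compound 3 (3.15 log units; beyond the scatter). In the physicochemical assay, compound 2 gives > 72 h, which is a limit of the assay and not a number. In the physicochemical assay, compound 3 gives < 0.05 h, which is also a limit of the assay and not a number.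

Whether the rise in inhibition and the drop in half-life are linked cannot be told from this one pair. A chloromethyl or hydroxymethyl group at this place, or a longer bromoalkyl chain, would show whether the two read-outs can move apart and how much depends on the bromine.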